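Compound 3 to compound 4: two inverted stereocentres

A few compounds are considered here, and "the series" means these few. Any claim that something is new, unique, unknown or untested is made for them only; others in the source may bear on it.

Working notes on the series. Compound 1 `C[C@@H]1C[C@H]2C(=O)C(C)(C)[C@H](O)CC[C@]2(O)[C@@]1(C)CCC1=CC(=O)OC1`, compound 2 `C[C@@H]1C[C@H]2C(=O)C(C)(C)[C@H](OC=O)CC[C@]2(O)[C@@]1(C)CCC1=CC(=O)OC1` and compound 3 `C[C@@H]1CC[C@@]2(O)[C@@H](C[C@@H](O)C2(C)C)C(=O)[C@@]1(C)CCC1=CC(=O)OC1` share one core and were measured in a functional assay on MCF7 cells (Homo sapiens) for cytotoxicity, read by MTT assay, with a stated time of 3 days; a lower number here means a stronger inhibitor, a higher number a weaker inhibitor. In this assay compound 1 gives only a limit, > 10000 nM. Compound 2 likewise gives only a limit in this assay, > 10000 nM. Among the compounds with values here, the one step between measured compounds that differ in a single place, a step that the two limits leave unreadable from compound 1 to compound 2, is therefore unreadable. Compound 3 also stands at a limit in this assay, > 10000 nM, so that the limit of > 10000 nM in this assay, at which 3 of the 3 values shown sit, describes every value obtained so far.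

Compound 4 `C[C@@H]1CC[C@]2(O)[C@H](C[C@@H](O)C2(C)C)C(=O)[C@@]1(C)CCC1=CC(=O)OC1` is not yet measured. Its difference from compound 3 is the two compounds have the same atoms and bonds and differ only in configuration as drawn: 2 of 5 stereo elements differ; a stereocentre at a saturated ring carbon is drawn R in compound 3 and S in compound 4; a stereocentre at a saturated ring carbon is drawn R in compound 3 and S in compound 4. Within the data shown here, no measured step involves a change of configuration, and the only step between measured compounds is unreadable, so nothing in the numbers bears on the size or direction of this change in this assay. Among the measured compounds shown here, with every value so far at the limit, compound 4 is expected to remain there as well, that is, a step that the limit leaves unreadable from compound 3 to compound 4 is estimated. For compound 4 the estimate in this assay is 20000 nM, within 5000 nM to 80000 nM.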

Compound 4, half-maximal inhibitory concentration: > 10000 nM
Compound 4 ended at the assay's limit (the forecaster's own chance of this, stated with the estimate: 85%); the middle value does not contradict the limit.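

In this assay compound 4 gives > 10000 nM, a limit and not a number. Compound 3 also stands at a limit, so no step can be read between compound 3 and compound 4. The compounds shown leave open whether the configuration at these two stereocentres affects activity in this assay, since none of them has a value inside the readable range.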